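This account rests on a few compounds, and the source may have more. Where it says the series, first, only, none or still open, it means among the compounds named here.

Measured in a functional assay on NCI/ADR-RES cells (Homo sapiens) for inhibition, read by sulforhodamine B assay, with a stated time of 48 h; a higher number here means a weaker inhibitor of growth, a lower number a stronger inhibitor of growth:
compound 1 `CC1=CC[C@H](C(C)(C)NC(=S)N/N=C/c2ccccc2)CC1` gives > 100000 nM, a limit of the assay.
compound 2 `CC1=CC[C@H](C(C)(C)NC(=S)N/N=C/c2ccc(N(C)C)cc2)CC1` gives > 100000 nM, a limit of the assay.
compound 3 `CC1=CC[C@H](C(C)(C)NC(=S)N/N=C/c2cccc(Cl)c2)CC1` gives > 100000 nM, a limit of the assay.

Compound 1 stands on a limit in this assay and nowhere else: no number is known for it, only > 100000 nM as the assay's limit. Compound 4 `CC1=CC[C@H](C(C)(C)NC(=S)N/N=C/c2ccc(Cl)cc2)CC1` differs from it by chloro in place of hydrogen on an aromatic carbon. The two steps measured from compound 1 are a step that the two limits leave unreadable from compound 1 to compound 2 and a step that the two limits leave unreadable from compound 1 to compound 3, and neither gives a size because of the limit of > 100000 nM in this assay, at which 3 of the 3 values shown sit. Nothing measured therefore tells whether the change to compound 4 moves the read-out up or down or leaves it within the scatter. With every value shown sitting on the limit, compound 4 is expected to return a limit as well, and its step from compound 1 is estimated at a step that the limit leaves unreadable from compound 1 to compound 4. The estimate for compound 4 is 150000 nM, with a range from 50000 nM to 500000 nM.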

Compound 4, concentration for total growth inhibition: 97400 nM
Compound 4: the middle estimate sits 1.5-fold (0.19 log units) above what was measured; the measured number falls inside the stated range.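

In this assay, compound 4 is the only compound shown that returns a number rather than a limit, which gives an at least 1.0-fold lower number from compound 1 to compound 4 (0.01 log units; that floor lies within the scatter), an at least 1.0-fold lower number from compound 3 to compound 4 (0.01 log units; that floor lies within the scatter) and an at least 1.0-fold lower number from compound 2 to compound 4 (0.01 log units; that floor lies within the scatter). For the compounds shown here, the change from phenyl to 4-chlorophenyl therefore yields the first readable value, with chloro on an aromatic carbon para to a large group, while compound 3, with 3-chlorophenyl, remains on a limit. These steps give only floors, with no true size and no firm order among the compounds, because the other three compounds have no number: the limit of > 100000 nM in this assay, at which 3 of the 4 values shown sit.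

On these data alone, how far compound 1, compound 2 and compound 3 actually lie from compound 4 stays open. Also open, as far as these compounds go, is whether bromo, methoxy or a carboxylic acid in the place of that chloro would return a number.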